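Ring Amine in Place of a Chain Amine on a Shared Core

The source may report more compounds than this note shows. Statements on the series, on what has been measured and on what is new or still open speak of the compounds shown alone.

Measured compounds:
- compound 1, `CC[C@H](C)C(N)c1cc(C(F)(F)F)ccc1N1CCN(C(=O)CCc2ccc(Cl)cc2Cl)CC1`: 75 nM
- compound 2, `CCC(C)CN[C@H](c1cc(C(F)(F)F)ccc1N1CCN(C(=O)CCc2ccc(Cl)cc2Cl)CC1)C(C)CC`: 2800 nM
- compound 3, `CCC(C)[C@H](NCCN)c1cc(C(F)(F)F)ccc1N1CCN(C(=O)CCc2ccc(Cl)cc2Cl)CC1`: 56 nM

These three share one core and differ only in the group on the aromatic carbon next to the core. In an assay on HEK293 cells for displacement of a labelled ligand from Melanocortin receptor 4 (Homo sapiens) (on this read-out lower numbers stand for stronger inhibition and higher numbers for weaker inhibition), compound 3 gives the lowest of the three numbers; compound 1 sits nearest to it, with a 1.3-fold lower number from compound 1 to compound 3 (0.13 log units; within the scatter), so the two cannot be told apart, while compound 2 is furthest, with a 50-fold lower number from compound 2 to compound 3 (1.70 log units; beyond the scatter).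

Compound 4, `CCC(C)[C@H](NC[C@@H]1CCCN1)c1cc(C(F)(F)F)ccc1N1CCN(C(=O)CCc2ccc(Cl)cc2Cl)CC1`, is not yet measured. It differs from compound 3 by pyrrolidin-2-yl in place of aminomethyl on a saturated chain carbon bound to an amine nitrogen. The free amine at the end of the chain thus becomes a ring nitrogen, but a nitrogen that can still donate and accept a hydrogen bond stays in place.

Among the compounds with values here, two measured steps bear on this. The step of a 50-fold lower number from compound 2 to compound 3 (1.70 log units; beyond the scatter) shows that putting an amine-bearing group at that chain position brings a large gain, and the step of a 1.3-fold lower number from compound 1 to compound 3 (0.13 log units; within the scatter) shows that the chain amine itself adds little over the bare amine of compound 1. Compound 4 keeps a nitrogen at the same distance, so no step beyond the scatter is expected. For compound 4 the estimate is 50 nM, within 15 nM to 200 nM, which means an expected step of a 1.1-fold lower number from compound 3 to compound 4 (0.05 log units; within the scatter).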

Compound 4, inhibition constant: 64 nM
For compound 4 the middle estimate is 1.3-fold (0.11 log units) below the measured one; low and high end bracket the measured number.
By their numbers in this assay, from the lowest: compounds 3, 4 and 1 (each within the scatter of the next); then compound 2.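

In this assay, the step from aminomethyl to pyrrolidin-2-yl on this saturated chain carbon, which goes from 2 heavy atoms to 5 and brings in a five-membered non-aromatic ring and a defined stereocentre, is a 1.1-fold higher number from compound 3 to compound 4 (0.06 log units; within the scatter), so the larger group and the smaller one cannot be told apart here. The ring-bearing chain also stands far from the sec-butyl chain, with a 44-fold lower number from compound 2 to compound 4 (1.64 log units; beyond the scatter), so the large gap first seen with aminomethyl appears with a second nitrogen-bearing group, while a 1.2-fold lower number from compound 1 to compound 4 (0.07 log units; within the scatter) leaves compound 4 indistinguishable from the simple amine of compound 1. No evidence is available on how the receptor accommodates the ring at this position.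

The compounds shown leave open whether the ring nitrogen is needed at all, a question that a cyclopentyl group, with a ring of the same size and only carbon atoms, would address directly. They also leave open how much room this position has for a larger piperidin-2-yl ring, and whether the mirror-image form of the pyrrolidin-2-yl group would read the same.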